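Hydroxy to Methoxy: One Step Toward Full Methylation

This account rests on a few compounds, and the source may have more. Where it says the series, first, only, none or still open, it means among the compounds named here.

Compound 2 `COc1cc(OC)cc(-c2cn(-c3ccc(OC)c(O)c3)nn2)c1` sits at the limit of a functional assay on MDA-MB-231 cells (Homo sapiens) for cytotoxicity, read by MTT assay; a lower number here means a stronger inhibitor, a higher number a weaker inhibitor; its value of > 10000 nM is a limit of the assay and not a number. Compound 1 `COc1ccc(-n2cc(-c3cc(O)cc(O)c3)nn2)cc1O` likewise reaches only a limit, > 10000 nM. Compound 3 `COc1ccc(-c2cn(-c3ccc(OC)c(OC)c3)nn2)cc1OC` shows "not determined" (no result reported) in this assay, so the picture rests on (the limit of > 10000 nM in this assay, at which 2 of the 3 values shown sit). Compound 4 `COc1cc(OC)cc(-c2cn(-c3ccc(OC)c(OC)c3)nn2)c1` differs from compound 2 by methyl in place of hydrogen on an oxygen on an aromatic ring; read one bond further out, hydroxy becomes methoxy. Going by the values given here, no step between measured compounds exists here, and the step estimated as a step that the limit leaves unreadable from compound 2 to compound 4 is none beyond the scatter. Compound 4 is therefore expected to give about 15000 nM, within 8000 nM to 30000 nM, most likely again as a limit.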

Compound 4, half-maximal inhibitory concentration: 10000 nM
Compound 4: the middle estimate sits 1.5-fold (0.18 log units) above what was measured; the measured number falls inside the stated range.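

In this assay, methyl in place of hydrogen on an oxygen on an aromatic ring gives a number no higher from compound 2 to compound 4 (the limit leaves the size open). Compound 4, which carries no hydroxy, returns a plain number, 10000 nM, something neither compound 1 nor compound 2 gives. Even so, the series stays at the edge of what the assay reads: the limit of > 10000 nM in this assay, at which 2 of the 4 values shown sit.

From the compounds shown here alone, the true size of this step stays open. So does whether an amine in place of the methoxy, or a longer chain on that oxygen, would move the value away from that edge.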